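From 3-chlorophenyl to 4-chlorophenyl: an expected antiproliferative value

This account rests on a few compounds, and the source may have more. Where it says the series, first, only, none or still open, it means among the compounds named here.

Within the data shown here, in a functional assay on MDA-MB-231 cells (Homo sapiens) for antiproliferative activity, read by MTT assay, with a stated time of 72 h (on this read-out lower numbers stand for stronger inhibition and higher numbers for weaker inhibition), compound 2 `NC1=NC2(CCSCC2)N(OCCCOc2cccc(Cl)c2)C(N)=N1` gives 130 nM as the only number available. For compound 1 `NC1=NC2(CCOCC2)N(OCCCOc2ccccc2)C(N)=N1` the entry reads "not determined" (no result reported) with no value behind it. For compound 3 `NC1=NC2(CCOCC2)N(OCCCOc2ccc(F)cc2)C(N)=N1` the entry reads "not determined" (no result reported) in the same way. Among the measured compounds shown here, compound 2 therefore stands alone, with no measured neighbour to rank it against and no measured step to show how far a single change can move this read-out.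

Compound 4 `NC1=NC2(CCSCC2)N(OCCCOc2ccc(Cl)cc2)C(N)=N1` has yet to be measured in this assay and keeps the shared core of compound 2. The two have the same atoms, joined differently, and the change 4-chlorophenyl in place of 3-chlorophenyl on an oxygen on a saturated carbon places 4-chlorophenyl in place of 3-chlorophenyl on an oxygen on a saturated carbon. For the measured compounds named here, the data offer no direction for this change, and the only anchor is compound 2 at 130 nM in this series. The estimated step of no change at the digits printed from compound 2 to compound 4 (within the scatter) is expected to stay within the usual scatter. Compound 4 is expected at 130 nM with an estimated range from 45 nM to 400 nM in this test.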

Compound 4, half-maximal inhibitory concentration: 350 nM
Compound 4: the middle estimate sits 2.7-fold (0.43 log units) below what was measured; the range from low to high includes it.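

Among these compounds, the first measured step shows that, on an oxygen on a saturated carbon, 4-chlorophenyl and 3-chlorophenyl are not interchangeable, even though the two compounds have the same atoms. In this assay the exchange gives a 2.7-fold higher number from compound 2 to compound 4 (0.43 log units; beyond the scatter) and so weaker inhibition, which favours 3-chlorophenyl over 4-chlorophenyl in this one pair and sets no pattern for other groups. Nothing measured here bears on why the two groups differ.

The compounds shown leave open how a 2-chlorophenyl group, a 3-bromophenyl group or a 3-methoxyphenyl group would compare at this place. They also leave open what a longer chain between the two oxygens would do, and whether the same exchange would give a step of similar size on the core of compound 3.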